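Cytotoxicity of Three Quinolinone Analogues and an Untested Fourth

A few compounds are considered here, and "the series" means these few. Any claim that something is new, unique, unknown or untested is made for them only; others in the source may bear on it.

Compound 1 `Cc1c(-c2ccc(Cc3ccc(C(C)(C)C)cc3)cc2)[nH]c2cccc(F)c2c1=O`: > 5000 nM
Compound 2 `Cc1c(-c2ccc(Cc3ccc(OCC(F)(F)F)cc3)cc2)[nH]c2cccc(F)c2c1=O`: > 5000 nM
Compound 3 `Cc1c(-c2ccc(Cc3ccc(C(C)(O)C(F)(F)F)cc3)cc2)[nH]c2cccc(F)c2c1=O`: > 2500 nM

In an ADME assay on Huh7.5.1 cells (Homo sapiens) for cytotoxicity, read by WST assay, with a stated time of 48 h (on this read-out lower numbers stand for higher toxicity in this test and higher numbers for lower toxicity in this test), none of the three compounds gives a number. Compound 3 stands only at a limit, (the limit of > 2500 nM in this assay, at which 1 of the 3 values shown sits). Compound 1 stands at the limit of > 5000 nM in this assay, at which 2 of the 3 values shown sit. Compound 2 stands at the same limit. The steps a step that the two limits leave unreadable from compound 1 to compound 2, a step that the two limits leave unreadable from compound 1 to compound 3 and a step that the two limits leave unreadable from compound 2 to compound 3 are therefore all unreadable in size, and nothing shows which compound is more or less toxic. Compound 4 `Cc1c(-c2ccc(Cc3ccc([S+]([O-])C(F)(F)F)cc3)cc2)[nH]c2cccc(F)c2c1=O` carries the change (a group of 6 heavy atoms (1 carbon, 1 oxygen, 3 fluorine, 1 sulfur; no ring) in place of a group of 7 heavy atoms (3 carbon, 1 oxygen, 3 fluorine; no ring), on an aromatic carbon). Within the data shown here, no measured step bears readably on this change. Among the measured compounds shown here, since every value so far is a limit, compound 4 is expected to remain beyond the assay's limit too, with a step that the limit leaves unreadable from compound 3 to compound 4 most likely unreadable. Compound 4 is estimated at 8000 nM, with a range from 2500 nM to 30000 nM.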

Compound 4, half-maximal cytotoxic concentration: > 5000 nM
Compound 4: only a limit was reported (the forecaster's own chance of this, stated with the estimate: 85%); the middle value is on the limit's open side.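

Among these compounds, compound 4 gives only a limit, as do compound 1, compound 2 and compound 3, so no step from any of them to compound 4 can be read. The compounds shown leave open whether changing this group alters cytotoxicity at all.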